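The source may report more compounds than this note shows. Statements on the series, on what has been measured and on what is new or still open speak of the compounds shown alone.

Measured so far in a functional assay on MCF7 cells (Homo sapiens) for inhibition; a higher number here means a weaker inhibitor, a lower number a stronger inhibitor:
Compound 1 `CC/C(=C(/c1ccc(/C=C/C(=O)O)cc1)c1cc2ccccc2[nH]1)c1ccccc1OC(F)(F)F`, giving 206 nM.
Compound 2 `CC/C(=C(/c1ccc(/C=C/C(=O)O)cc1)c1cc2ccccc2[nH]1)c1ccc(C#N)cc1`, giving 278 nM.

Compound 2 holds the higher of the two numbers in this assay, but its separation from compound 1 is only a 1.3-fold higher number from compound 1 to compound 2 (0.13 log units; within the scatter), which stays within the scatter, so no order between the two can be read from these values.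

The next compound, compound 3 `CC/C(=C(/c1ccc(/C=C/C(=O)O)cc1)c1cc2ccccc2[nH]1)c1ccc(C(F)(F)F)cc1`, differs from compound 2 by trifluoromethyl in place of cyano on an aromatic carbon. Going by the values given here, only one measured step speaks to this place on the shared core: the exchange of the aryl group going from compound 1 to compound 2, which came out at a 1.3-fold higher number from compound 1 to compound 2 (0.13 log units; within the scatter). That step replaced the whole substituted phenyl ring rather than the substituent alone, so it bears on the present change only loosely, and it was itself within the scatter. Nothing measured here separates the cyano and trifluoromethyl groups at this position.

On that basis the step from compound 2 to compound 3 in this assay is expected to be small, a 1.1-fold lower number from compound 2 to compound 3 (0.05 log units; within the scatter), with no direction claimed beyond the scatter. Compound 3 is therefore estimated at 250 nM, within a range of 110 nM to 560 nM.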

Compound 3, half-maximal inhibitory concentration: 139 nM
For compound 3 the middle estimate is 1.8-fold (0.25 log units) above the measured one; the range from low to high includes it.
By their numbers in this assay, from the lowest: compounds 3, 1 and 2 (each within the scatter of the next).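

Notes on the series: in this assay, the exchange of trifluoromethyl for cyano on an aromatic carbon para to a large group tests the substituent alone for the first time at this place, and the step stays within the scatter (a 2.0-fold lower number from compound 2 to compound 3 (0.30 log units; within the scatter)). The comparison of the 4-(trifluoromethyl)phenyl and 2-(trifluoromethoxy)phenyl groups also stays within the scatter (a 1.5-fold lower number from compound 1 to compound 3 (0.17 log units; within the scatter)), so the three aryl groups on the shared core fall into no order, and groups of different heavy-atom counts, cyano and trifluoromethyl, give values that cannot be told apart. No accompanying measurement offers an explanation for these values.

Open is whether this place stays as flat with an amine, a hydroxyl group or a longer alkyl chain on the ring, since the compounds shown carry only the cyano, trifluoromethyl and trifluoromethoxy groups. Also open, on these data alone, is whether the values hold when the carboxylic acid of the shared core gives way to an amide or an ester, as that part is the same in all three compounds.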